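Swapping Trifluoromethoxy for Trifluoromethyl in a Urea Series

The source may hold more compounds than are shown below. What is called first, only, known or untested is meant among the compounds shown, and "the series" means these compounds.

Measured so far in a physicochemical assay for lipophilicity, read by HPLC, with a stated time of 90 min, tested at 100 uM (a lower number here means a more polar compound, a higher number a more lipophilic compound), are two compounds:
Compound 1 `O=C(Nc1ccc(C(F)(F)F)cc1)NC1CCN(C(=O)C2CCCOC2)CC1` gives 3.41 here
Compound 2 `O=C(Nc1ccc(OC(F)(F)F)cc1)NC1CCN(C(=O)C2CCOC2)CC1` gives 3.22 here

In this assay compound 2 stands at 3.22 and lies within the usual scatter of compound 1 at 3.41 on this scale. The two compounds differ in more than one place, so their values do not isolate any single change.

Compound 3 `O=C(Nc1ccc(C(F)(F)F)cc1)NC1CCN(C(=O)C2CCOC2)CC1` has not yet been measured. It keeps the rest of compound 2 but carries trifluoromethyl in place of trifluoromethoxy on an aromatic carbon in the same place, para to a large group.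

Going by the values given here, no measured pair shows this change alone. Among the compounds with values here, the expectation therefore starts from compound 2 at 3.22 as the only measured compound that differs from compound 3 in one place. A small downward step is expected in this assay and may not clear the usual scatter. The estimated step is a number 0.17 log units lower from compound 2 to compound 3 (within the scatter) on this scale. For compound 3 the expected value is 3.05 with an estimated range from 2.75 to 3.35 on this scale.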

Compound 3, partition coefficient: 3.16
For compound 3 the middle estimate is 0.11 log units below the measured one; the range from low to high includes it.
By their numbers in this assay, from the lowest: compounds 3, 2 and 1 (each within the scatter of the next).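

Going by these compounds alone, the first reading of this exchange alone comes from this assay where trifluoromethyl in place of trifluoromethoxy on an aromatic carbon, para to a large group, gives a number 0.06 log units lower from compound 2 to compound 3 (within the scatter) and so leaves the two groups indistinguishable at this position on this scale. Within the data shown here, compound 3 also supplies the first single-place comparison at the other end of the molecule: oxolan-3-yl in place of oxan-3-yl on a carbonyl carbon gives a number 0.25 log units lower from compound 1 to compound 3 (within the scatter) so that neither exchange, read on its own, separates the compounds it joins. Nothing at hand bears on why either exchange gives so small a step.

Among these compounds, what remains open is whether the match between trifluoromethyl and trifluoromethoxy holds with oxan-3-yl on the carbonyl carbon, since both single-place readings rest on the one oxolan-3-yl compound 3 as their shared partner. Going by these compounds, it is also open how a group of another kind on the same aromatic carbon, such as a nitrile, an amine or a carboxylic acid, would read against these compounds on this scale.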